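Benzyl in place of hydrogen on compound 2

A few compounds are considered here, and "the series" means these few. Any claim that something is new, unique, unknown or untested is made for them only; others in the source may bear on it.

Two compounds of the series have numbers in a functional assay on the whole organism (Tail, strain ICR) with Mus musculus as the target, in the tail flick test, with a stated time of 120 min, at a dose of 25 umol/kg by the oral route; on this read-out lower numbers stand for a weaker effect and higher numbers for a stronger effect at the one dose given. Compound 1 `N=C(N)NCCC[C@H](NC(=O)CN(c1nc(Cl)nc2[nH]cnc12)C1CC1)C(=O)OCc1ccccc1` gives 10.2% in this assay. Compound 2 `NC(=O)C[C@H](NC(=O)CN(c1nc(Cl)nc2[nH]cnc12)C1CC1)C(=O)O` gives 17% in this assay, the higher of the two numbers, though the gap to compound 1 lies within the scatter, so the two read as alike. Compound 3 `NC(=O)C[C@H](NC(=O)CN(c1nc(Cl)nc2[nH]cnc12)C1CC1)C(=O)OCc1ccccc1` is compound 2 with one change: benzyl in place of hydrogen on an oxygen next to a carbonyl group. For the measured compounds named here, no pair differing in one place has been measured, so nothing can be said of how large such a change tends to be. Compound 1 also carries benzyloxycarbonyl in place of carboxy and sits no higher than compound 2. The step of a number 5 percentage points lower from compound 2 to compound 3 (within the scatter) is thus expected to be small and, if anything, downward, not beyond the scatter. Compound 3 is estimated at 12% in this assay, within 3% to 25%.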

Compound 3, a percentage reported as activity, at one dose (the size of the read-out at that dose, not a potency): 15.1%
The estimate for compound 3 lay 3.1 percentage points below the measured number, and the stated range covers the measured number.
By their numbers in this assay, from the lowest: compounds 1, 3 and 2 (each within the scatter of the next).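

In this assay, for the compounds shown here, benzyl in place of hydrogen on an oxygen next to a carbonyl group gives a number 1.9 percentage points lower from compound 2 to compound 3 (within the scatter), the first single-place reading at this position, so carboxy and benzyloxycarbonyl read as alike on this side chain. With benzyloxycarbonyl held constant, the side-chain exchange gives a number 4.9 percentage points higher from compound 1 to compound 3 (within the scatter), so the group of 3 heavy atoms and the group of 6 heavy atoms on the saturated chain carbon also read as alike. No evidence on the reason for either result is available.

Open, on these data alone, is whether a methyl ester or a primary amide in place of benzyloxycarbonyl would read as alike at this position. Also open, as far as these compounds go, is whether carboxy in place of benzyloxycarbonyl on compound 1 would read as alike, which would show whether the benzyl step carries over to the other side chain.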